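Moving the chlorine on the aryl group of a thiosemicarbazone

A few compounds are considered here, and "the series" means these few. Any claim that something is new, unique, unknown or untested is made for them only; others in the source may bear on it.

Measured compounds, with their numbers in a functional assay on OVCAR-3 cells (Homo sapiens) for inhibition, read by sulforhodamine B assay, with a stated time of 48 h; a higher number here means a weaker inhibitor of growth, a lower number a stronger inhibitor of growth:
Compound 1, `COc1ccc(/C=N/NC(=S)NC(C)(C)[C@H]2CC=C(C)CC2)cc1`, gives 7900 nM.
Compound 2, `CC1=CC[C@H](C(C)(C)NC(=S)N/N=C/c2cccc(Cl)c2)CC1`, gives 13600 nM.

Compound 2 has the higher of the two numbers, but the step of a 1.7-fold higher number from compound 1 to compound 2 (0.24 log units; within the scatter) is within the scatter, so the two are not separated. Compound 3, `CC1=CC[C@H](C(C)(C)NC(=S)N/N=C/c2ccc(Cl)cc2)CC1`, differs from compound 2 by 4-chlorophenyl in place of 3-chlorophenyl on a carbon with a double bond to nitrogen. Within the data shown here, the only measured step touching this position, a 1.7-fold higher number from compound 1 to compound 2 (0.24 log units; within the scatter), swapped both substituent and position and stayed within the scatter, so no step beyond the scatter is expected here. Compound 3 is therefore estimated at 11000 nM, in the range 4000 nM to 30000 nM, a step of a 1.2-fold lower number from compound 2 to compound 3 (0.09 log units; within the scatter).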

Compound 3, concentration for 50% growth inhibition: 8600 nM
Estimate against measurement, compound 3: 1.3-fold (0.11 log units) above; low and high end bracket the measured number.
By their numbers in this assay, from the lowest: compounds 1, 3 and 2 (each within the scatter of the next).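

In this assay, moving the chlorine gave a 1.6-fold lower number from compound 2 to compound 3 (0.20 log units; within the scatter), so 3-chlorophenyl and 4-chlorophenyl are not told apart on this carbon with a double bond to nitrogen. Chloro in place of methoxy on an aromatic carbon, now seen on its own without a shift of position, gave a 1.1-fold higher number from compound 1 to compound 3 (0.04 log units; within the scatter), so these two are not separated either. Nothing at hand speaks to the reason for these results. The compounds shown leave open whether an amine or a carboxylic acid on the aromatic ring would give a step beyond the scatter.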